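Iodo in place of bromo in two compound pairs

The compounds below may be only part of what the source reports. "The series", "measured", "known", "first", "only" and "open" are said of these compounds alone.

Measured compounds:
compound 1, `O=C(Nc1cccc(Br)c1)C(Cl)Cl`, 95300 nM
compound 2, `O=C(Nc1cccc(I)c1)C(Cl)Cl`, 58800 nM
compound 3, `O=C(Nc1ccc(Br)cc1)C(Cl)Cl`, "not determined" (no result reported)

In a functional assay on BGC-823 cells (Homo sapiens) for antiproliferative activity, read by MTT assay, with a stated time of 72 h (on this read-out higher numbers stand for weaker inhibition and lower numbers for stronger inhibition), compound 1 gives 95300 nM and compound 2 gives 58800 nM. The two differ by iodo in place of bromo on an aromatic carbon, and the step of a 1.6-fold lower number from compound 1 to compound 2 (0.21 log units; within the scatter) shows that the exchange left the read-out in this assay essentially unchanged.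

Compound 3, `O=C(Nc1ccc(Br)cc1)C(Cl)Cl`, has no single number in this assay; its entry reads "not determined" (no result reported). Its core is made of the same atoms as the core of compound 1, joined differently; the difference between the two cores is not broken down here. Compound 4, `O=C(Nc1ccc(I)cc1)C(Cl)Cl`, differs from compound 3 by iodo in place of bromo on an aromatic carbon. Going by the values given here, this is the same kind of change as the one from compound 1 to compound 2, but the place is not the same: there the entering group stood meta to a group of 6 heavy atoms, here it stands para to a group of 6 heavy atoms.

With no single number for compound 3, the expectation for compound 4 rests only on compound 1, which gives 95300 nM, and on compound 2, which gives 58800 nM; these two values lie within the scatter of each other. Compound 4 is therefore expected to give a number in this assay near 65000 nM, with a wide range from 20000 nM to 200000 nM, since the effect of the changed core is not measured.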

Compound 4, half-maximal inhibitory concentration: 222000 nM
Estimate against measurement, compound 4: 3.4-fold (0.53 log units) below, and the stated range ends below it.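

In this assay, going by these compounds alone, compound 3 has no single number, so no step from it to compound 4, which gives 222000 nM, can be read. The compounds shown leave open what iodo in place of bromo does to the read-out when para to a group of 6 heavy atoms. Nothing shown here offers an explanation for this value.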